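The compounds below may be only part of what the source reports. "The series", "measured", "known", "first", "only" and "open" are said of these compounds alone.

Compound 1 `COc1ccc2nc(C)cc(OCC(=O)Nc3cc(C)cc(C)c3)c2c1` and compound 2 `COc1ccc2nc(C)cc(OCC(=O)Nc3cc(C)ccc3C)c2c1` share one core and differ only in the aryl group carried on the amide-type nitrogen. In a toxicity assay on HepG2 cells (Homo sapiens) for inhibition, read by CellTiter-Glo, with a stated time of 48 h (a higher number here means a weaker inhibitor, a lower number a stronger inhibitor), compound 1 gives 20000 nM. For compound 2 the same assay reports only a limit, > 100000 nM, so no exact number is known for it. The step of an at least 5.0-fold higher number from compound 1 to compound 2 (0.69 log units; beyond the scatter) thus places the 2,5-dimethylphenyl compound at the weak end of what the assay resolves, as recorded by the limit of > 100000 nM in this assay, at which 1 of the 2 values shown sits.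

Compound 3 `COc1ccc(NC(=O)COc2cc(C)nc3ccc(OC)cc23)cc1` has not yet been measured. It differs from compound 2 in that (4-methoxyphenyl in place of 2,5-dimethylphenyl on an amide-type nitrogen). Within the data shown here, no measured step carries this exact change; the only guide is that compound 2 sits at a limit while compound 1, with a different dimethylphenyl group, returns a number, so the room for a further rise is small and a fall back toward a measurable value is as likely as not. The expected step of an at least 2.0-fold lower number from compound 2 to compound 3 (0.30 log units; that floor lies within the scatter) is therefore modest. Compound 3 is expected to give about 50000 nM in this assay, with a range from 15000 nM to 100000 nM.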

Compound 3, half-maximal inhibitory concentration: > 100000 nM
Compound 3: a limit, no number (the forecaster's own chance of this, stated with the estimate: 45%); at least 2.0-fold (0.30 log units) between middle value and limit.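

In this assay, the 4-methoxyphenyl group on the amide-type nitrogen behaves as the 2,5-dimethylphenyl group does, so a second aryl group, this one carrying an oxygen, leaves the read-out at a limit rather than a number: the limit of > 100000 nM in this assay, at which 2 of the 3 values shown sit.

Replacing the 3,5-dimethylphenyl group with 4-methoxyphenyl gives an at least 5.0-fold higher number from compound 1 to compound 3 (0.69 log units; beyond the scatter), so a change at this position that keeps the heavy-atom count of the group still moves the result beyond the scatter. Because compound 2 and compound 3 both stand at a limit, the step between them cannot be read, and compound 1 remains the only one of the three with a number.

The compounds shown leave open whether that number depends on the 3,5-dimethylphenyl group in particular or would also appear with a plain phenyl, a chlorophenyl or a pyridyl group on the amide-type nitrogen. They also leave open how far beyond the limit compound 2 and compound 3 lie, and whether a change elsewhere on the shared core, such as an amine in place of the methoxy group, would alter the picture.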